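The source may hold more compounds than are shown below. What is called first, only, known or untested is meant among the compounds shown, and "the series" means these compounds.

Measured so far in a physicochemical assay for lipophilicity; on this read-out higher numbers stand for higher lipophilicity and lower numbers for lower lipophilicity:
- compound 1 `CC(C)(C)C#Cc1cc(N(C(=O)[C@H]2CC[C@H](C)CC2)[C@H]2CC[C@H](Oc3ccc4nccn4n3)CC2)c(C(=O)O)s1` gives 2.4
- compound 2 `CC(C)(C)C#Cc1cc(N(C(=O)[C@H]2CC[C@H](C)CC2)[C@H]2CC[C@H](OC3COC3)CC2)c(C(=O)O)s1` gives 2.6
- compound 3 `CC(C)(C)C#Cc1cc(N(C(=O)[C@H]2CC[C@H](C)CC2)[C@H]2CC[C@H](Oc3ccncn3)CC2)c(C(=O)O)s1` gives 2.3

Compound 1 stands within the scatter of both other compounds. Compound 4 `CC(C)(C)C#Cc1cc(N(C(=O)[C@H]2CC[C@H](C)CC2)[C@H]2CC[C@H](Oc3ccccn3)CC2)c(C(=O)O)s1` differs from compound 1 by a group of 6 heavy atoms (5 carbon, 1 nitrogen; one six-membered aromatic ring with 1 hetero atom) in place of a group of 9 heavy atoms (6 carbon, 3 nitrogen; one five-membered aromatic ring with 2 hetero atoms, one six-membered aromatic ring with 2 hetero atoms), on an oxygen on a saturated carbon and so carries pyridin-2-yl on that oxygen. Within the data shown here, no measured step makes this exact change. Among the measured compounds shown here, three steps bear on it: a number 0.10 log units lower from compound 1 to compound 3 (within the scatter) with pyrimidin-4-yl entering, a number 0.20 log units higher from compound 1 to compound 2 (within the scatter) with oxetan-3-yl entering, and a number 0.30 log units lower from compound 2 to compound 3 (within the scatter) between those two groups. All three stay within the scatter, so only a slight rise is expected, with the estimated step of a number 0.30 log units higher from compound 1 to compound 4 (within the scatter) in this read-out. For compound 4 the estimated value is 2.7 with an expected range from 2.3 to 3.1 in the same units.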

Compound 4, distribution coefficient: 3
Beside the measured number, compound 4's estimate is 0.30 log units below it, and the stated range covers the measured number.
By their numbers in this assay, from the lowest: compounds 3, 1 and 2 (each within the scatter of the next); then compound 4.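

Among these compounds, at this place on the oxygen, this assay now shows steps beyond the scatter, which no earlier pair showed: a number 0.60 log units higher from compound 1 to compound 4 (beyond the scatter) and a number 0.40 log units higher from compound 2 to compound 4 (beyond the scatter) and also a number 0.70 log units higher from compound 3 to compound 4 (beyond the scatter) with pyridin-2-yl entering. Compound 4 thus stands apart from the other three compounds, which all lie within the scatter of one another. Nothing at hand explains why this group stands apart. Going by these compounds, whether phenyl or pyridin-3-yl on that oxygen would read with compound 4 or with the other three stays open.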